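Sulfonyl aryl swap in the hydrazide series

The source may report more compounds than this note shows. Statements on the series, on what has been measured and on what is new or still open speak of the compounds shown alone.

Compound 1 (`CC(=O)Nc1ccc(S(=O)(=O)NNC(=O)c2cccnc2Nc2ccc(Cl)cc2)cc1`) is the reference point. In a functional assay on UACC-62 cells (Homo sapiens) for antiproliferative activity (a higher number here means that more compound is tolerated, a lower number that less compound is tolerated), compound 1 returns only a limit, > 100000 nM, not a number. Compound 2 (`O=C(NNS(=O)(=O)c1ccc(F)cc1)c1cccnc1Nc1ccc(Cl)cc1Cl`) is the other measured member, and in this assay compound 2 likewise gives a limit, > 100000 nM. No step between measured compounds can be drawn; what is shown is the limit of > 100000 nM in this assay, at which 2 of the 2 values shown sit, so compound 1 stands at the limit with one further limit beside it. Compound 3 (`O=C(NNS(=O)(=O)c1ccc(Cl)cc1Cl)c1cccnc1Nc1ccc(Cl)cc1`) carries the change (2,4-dichlorophenyl in place of 4-acetamidophenyl on a sulfonyl sulfur), that is, 2,4-dichlorophenyl in place of 4-acetamidophenyl on a sulfonyl sulfur. With both measured values sitting at the limit, no step beyond the scatter is expected in this assay for compound 3, in either direction. The expected step from compound 1 to compound 3 is a number no higher from compound 1 to compound 3 (the limit leaves the size open), essentially none. Compound 3 is therefore estimated at 100000 nM, within 30000 nM to 300000 nM, most likely again reported only as a limit.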

Compound 3, concentration lethal to 50% of the cells: > 100000 nM
Compound 3: no number, only a limit (the forecaster's own chance of this, stated with the estimate: 80%); the middle value lies on the limit itself.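

In this assay compound 3 gives > 100000 nM, a limit and not a number. For the compounds shown here, compound 1 also stands at a limit, so no step from compound 1 to compound 3 can be read. The compounds shown leave open which sulfonyl aryl group, if any, would give a numerical value in this assay.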